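The compounds below may be only part of what the source reports. "The series", "measured", "known", "first", "only" and "open" are said of these compounds alone.

Three compounds of this series have been run in a functional assay on the whole organism (plasma, strain albino) for inhibition, with Rattus norvegicus as the target, with stated times of 1 h and 4 h, at a dose of 25 mg/kg by the oral route; on this read-out higher numbers stand for a stronger effect at the one dose given and lower numbers for a weaker effect. Compound 1 `COc1ccc(C2CC(c3ccc(NC(=O)c4cc(Cl)ccc4OC)cc3)=NN2C)cc1` gives 69.6%, compound 2 `COc1ccc(C2CC(c3ccc(NC(=O)c4cc(Cl)ccc4OC)cc3)=NN2c2ccccc2)cc1` gives 82.3%, and compound 3 `COc1ccc(Cl)cc1C(=O)Nc1ccc(C2=NN(c3ccccc3)C(c3ccccc3[N+](=O)[O-])C2)cc1` gives 73.3%. Compound 2 holds the highest of the three numbers: a number 12.7 percentage points higher from compound 1 to compound 2 (beyond the scatter), while a number 9 percentage points lower from compound 2 to compound 3 (within the scatter).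

Compound 4 `COc1ccc(C2CC(c3ccc(NC(=O)c4cc(Cl)ccc4OC)cc3)=NN2C(C)=O)cc1` remains to be measured. Against compound 2 the change is acetyl in place of phenyl on an amine nitrogen in a ring. For the measured compounds named here, the only measured step that touches the same amine nitrogen in a ring is the one from methyl to phenyl, a number 12.7 percentage points higher from compound 1 to compound 2 (beyond the scatter). The step from compound 2 to compound 3 concerns a saturated ring carbon and does not bear on it. Going by the values given here, no measured compound carries acetyl, so a direct comparison is lacking; the expectation rests on the phenyl leaving again, which in compound 1 was absent.

The expected step is a number 14.3 percentage points lower from compound 2 to compound 4 (beyond the scatter), a reversal of roughly the size seen on going from compound 1 to compound 2, though it may fall within the scatter. In this assay compound 4 is therefore estimated at 68%, with a range of 52% to 82%.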

Compound 4, a percentage reported as inhibition, in the whole organism at one dose (the size of the read-out at that dose, not a potency): 79.4%
Estimate against measurement, compound 4: 11.4 percentage points below; the range from low to high includes it.
By their numbers in this assay, from the lowest: compounds 1, 3, 4 and 2 (each within the scatter of the next, the first and the last beyond it).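

In this assay, acetyl, which has no ring, takes the place of phenyl on the amine nitrogen in a ring without a change beyond the scatter (a number 2.9 percentage points lower from compound 2 to compound 4 (within the scatter)), so among these compounds an aromatic ring on this nitrogen is not needed to stay level with compound 2. Acetyl also stays within the scatter of methyl (a number 9.8 percentage points higher from compound 1 to compound 4 (within the scatter)), so it cannot be ordered against either group, and only the step between those two lies beyond the scatter (a number 12.7 percentage points higher from compound 1 to compound 2 (beyond the scatter)). Nothing measured here accounts for this result.

Open, from the compounds shown here alone, is how a longer acyl chain, a sulfonyl group or a substituted phenyl would read on this nitrogen. Also open, going by these compounds, is whether acetyl would hold up alongside 2-nitrophenyl on the saturated ring carbon, and since every number comes from a single dose, none of this speaks to potency.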